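The compounds below may be only part of what the source reports. "The series", "measured", "known", "first", "only" and "open" are said of these compounds alone.

For the measured compounds named here, compound 3, `CS(=O)(=O)Nc1ccc2nccc(-c3ccncc3)c2n1`, is the one member of this small set with a real number in a physicochemical assay for solubility, read by HPLC, using the shake flask method, measured as kinetic solubility, with a stated time of 20 h, at pH 6.5, tested at 200 uM; on this read-out lower numbers stand for lower solubility and higher numbers for higher solubility: compound 3 gives 90000 nM. Compound 1, `Nc1cccc(-c2ccc3nccc(-c4ccncc4)c3n2)c1`, sits at a limit of the assay, < 5000 nM. Compound 2, `NS(=O)(=O)c1cccc(-c2ccc3nccc(-c4ccncc4)c3n2)c1`, likewise shows only a limit, < 5000 nM. Compound 4, `c1cc(-c2ccnc3ccc(NC4CC4)nc23)ccn1`, differs from compound 3 by cyclopropyl in place of methylsulfonyl on a nitrogen on an aromatic ring. Going by the values given here, of the measured steps, a step that the two limits leave unreadable from compound 1 to compound 2 stays unreadable, while an at least 18-fold higher number from compound 1 to compound 3 (1.25 log units; beyond the scatter) shows how far compound 3 rises once the 3-aminophenyl gives way to methanesulfonamido; with two values sitting at the limit of < 5000 nM in this assay, at which 2 of the 3 values shown sit, no step tests the methylsulfonyl itself. Compound 4 is therefore expected to land somewhat lower than compound 3, an estimated step of a 3.0-fold lower number from compound 3 to compound 4 (0.48 log units; beyond the scatter), giving an expected 30000 nM within 8000 nM to 90000 nM.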

Compound 4, solubility: 90000 nM
Estimate against measurement, compound 4: 3.0-fold (0.48 log units) below; the measured number falls inside the stated range.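

In this assay, cyclopropyl in place of methylsulfonyl on a nitrogen on an aromatic ring gives no change at the digits printed from compound 3 to compound 4 (within the scatter), so the methylsulfonyl is not needed for the reading of compound 3. Cyclopropylamino in place of 3-aminophenyl gives an at least 18-fold higher number from compound 1 to compound 4 (1.25 log units; beyond the scatter), so a second, sulfur-free group at this place also stands well clear of compound 1. That step starts from a limit of the assay, not a number: the limit of < 5000 nM in this assay, at which 2 of the 4 values shown sit.

On these data alone, whether a longer alkyl chain, a carboxylic acid or a plain amino group at this place would read the same stays open.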